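Working notes: 4-chlorobenzyl to 4-methylbenzyl

This account rests on a few compounds, and the source may have more. Where it says the series, first, only, none or still open, it means among the compounds named here.

- compound 1 `COc1ccc(Cc2nnc(NC(=O)/C(C#N)=C/c3ccccc3OS(=O)(=O)c3ccc(C)cc3)s2)cc1`: 70%
- compound 2 `Cc1ccc(S(=O)(=O)Oc2ccccc2/C=C(\C#N)C(=O)Nc2nnc(Cc3ccc(Cl)cc3)s2)cc1`: 69%

For the measured compounds named here, in a functional assay on RS4-11 cells (Homo sapiens) for inhibition, read by CCK-8 assay, with a stated time of 48 h, tested at 20 uM (on this read-out higher numbers stand for more inhibition of growth at the one concentration tested and lower numbers for less inhibition of growth), compound 2 gives 69%, which lies within the scatter of compound 1, the only other measured compound. Compound 3 `Cc1ccc(Cc2nnc(NC(=O)/C(C#N)=C/c3ccccc3OS(=O)(=O)c3ccc(C)cc3)s2)cc1` has methyl in place of chloro on an aromatic carbon, para to a large group: methyl in place of chloro on an aromatic carbon. The 4-chlorobenzyl group of compound 2 thus becomes 4-methylbenzyl.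

Going by the values given here, one measured step bears on this change, as it involves the same aromatic carbon: a number 1 percentage points lower from compound 1 to compound 2 (within the scatter). Among the compounds with values here, this single step within the scatter is thin evidence, and no measured compound yet carries the methyl group. On this basis, no change beyond the scatter is expected. The expected step is no change at the digits printed from compound 2 to compound 3 (within the scatter). Compound 3 is estimated at 69%, with an expected range of 57% to 80%.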

Compound 3, percent growth inhibition at one concentration: 66%
For compound 3 the middle estimate is 3 percentage points above the measured one; the measured number falls inside the stated range.
By their numbers in this assay, from the lowest: compounds 3, 2 and 1 (each within the scatter of the next).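

In this assay the change from chloro to methyl is a number 3 percentage points lower from compound 2 to compound 3 (within the scatter), and the change from methoxy to methyl is a number 4 percentage points lower from compound 1 to compound 3 (within the scatter). Methoxy, chloro and methyl on this aromatic carbon, para to a large group, therefore cannot be told apart on this read-out, a finding that now spans three groups across compound 1, compound 2 and compound 3. Nothing measured here offers an explanation for this flat result.

Going by these compounds, whether an amine, a carboxylic acid or a longer chain at the same place would move the number beyond the scatter remains open. Also open, on these data alone, is whether these three compounds would stay this close at other concentrations, as all the values shown come from a single tested concentration.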